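Pyridin-2-yl for pyrimidin-2-yl on the sulfonamide nitrogen

The compounds below may be only part of what the source reports. "The series", "measured", "known", "first", "only" and "open" are said of these compounds alone.

Compound 2 `O=c1c(CNc2ccc(S(=O)(=O)Nc3ncccn3)cc2)coc2ccccc12` carries a pyrimidin-2-yl on its sulfonamide nitrogen, and in a functional assay on A549 cells (Homo sapiens) for cytotoxicity, read by sulforhodamine B assay, with a stated time of 72 h (a higher number here means a weaker inhibitor, a lower number a stronger inhibitor), compound 2 gives 85300 nM. Compound 1 `O=c1c(CNc2ccc(S(=O)(=O)Nc3ccccn3)cc2)coc2ccccc12` differs from it in one place: pyridin-2-yl in place of pyrimidin-2-yl on a sulfonamide nitrogen. In this assay compound 1 reaches > 100000 nM, which is a limit of the assay and not a number. The step of an at least 1.1-fold higher number from compound 2 to compound 1 (0.06 log units; that floor lies within the scatter) is thus known only as a floor, because one of the values sits at the limit of > 100000 nM in this assay, at which 1 of the 3 values shown sits.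

Compound 3 `O=C1/C(=C/c2coc3ccccc3c2=O)N=C(c2ccccc2)N1c1ccc(S(=O)(=O)Nc2ncccn2)cc1` rests on a different core; the difference between the two cores is not broken down here. In this assay compound 3 gives 40500 nM, the lowest of the two numbers at hand.

Compound 4 `O=C1/C(=C/c2coc3ccccc3c2=O)N=C(c2ccccc2)N1c1ccc(S(=O)(=O)Nc2ccccn2)cc1` repeats the change on the core of compound 3: pyridin-2-yl in place of pyrimidin-2-yl on a sulfonamide nitrogen. The place is the same in both pairs, so this is the same change. On the core of compound 3 it is expected to give a 1.7-fold higher number from compound 3 to compound 4 (0.24 log units; within the scatter), resting on the direction of an at least 1.1-fold higher number from compound 2 to compound 1 (0.06 log units; that floor lies within the scatter), though that earlier step is only a floor. The estimate for compound 4 in this assay is 70000 nM, within 35000 nM to 150000 nM, with a real chance that only a limit is reported.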

Compound 4, half-maximal inhibitory concentration: > 100000 nM
Compound 4: a limit, no number; the forecaster's own chance of this, stated with the estimate: 40%; middle value at least 1.4-fold (0.15 log units) away from the limit.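

In this assay compound 4 gives > 100000 nM, which is a limit of the assay and not a number. Pyridin-2-yl in place of pyrimidin-2-yl on the sulfonamide nitrogen gives an at least 2.4-fold higher number from compound 3 to compound 4 (0.39 log units; beyond the scatter), so the change clearly raises the number on this core, even though the step is known only as a floor, whereas the floor on the core of compound 2 lies within the scatter and does not establish a direction there by itself. The notes therefore support a loss on one core and are compatible with the same loss on the other, but they do not show that the size of the step carries over: the same change on two cores in this assay, an at least 1.1-fold higher number (0.06 log units; that floor lies within the scatter) from compound 2 to compound 1 and an at least 2.4-fold higher number (0.39 log units; beyond the scatter) from compound 3 to compound 4; the limit leaves it open whether they differ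

Still open, as far as these compounds go, is how this assay would read with a thiazol-2-yl or a plain phenyl on the sulfonamide nitrogen, on either core. Also open is whether a pyrimidin-2-yl bearing methyl groups would hold the number of the parent pyrimidin-2-yl compounds, or join the pyridin-2-yl compounds at the limit: the limit of > 100000 nM in this assay, at which 2 of the 4 values shown sit.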